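A Chlorine-to-Bromine Swap on an Already Inactive Core

The source may hold more compounds than are shown below. What is called first, only, known or untested is meant among the compounds shown, and "the series" means these compounds.

Compound 1 `CO[C@@H]1[C@H](N(C)c2ncc(-c3c[nH]c4ccccc34)s2)C[C@H]2O[C@]1(C)n1c3ccccc3c3c4c(c5c6cc(Cl)ccc6n2c5c31)C(=O)NC4` gives > 10000 nM in a functional assay on HL-60 cells (Homo sapiens) for antiproliferative activity, read by CellTiter-Glo, with a stated time of 72 h (a higher number here means a weaker inhibitor, a lower number a stronger inhibitor), a limit of the assay rather than a number.
Compound 2 `CO[C@@H]1[C@H](N(C)c2ncc(-c3c[nH]c4ccc(Cl)cc34)s2)C[C@H]2O[C@]1(C)n1c3ccccc3c3c4c(c5c6cc(Cl)ccc6n2c5c31)C(=O)NC4` gives > 10000 nM, likewise a limit.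

Both measured values sit at the limit of > 10000 nM in this assay, at which 2 of the 2 values shown sit, so compound 1 stands only at a limit with no number beneath it. Going by the values given here, the single measured step, a step that the two limits leave unreadable from compound 1 to compound 2, cannot be sized. Compound 3 `CO[C@@H]1[C@H](N(C)c2ncc(-c3c[nH]c4ccccc34)s2)C[C@H]2O[C@]1(C)n1c3ccccc3c3c4c(c5c6cc(Br)ccc6n2c5c31)C(=O)NC4` differs from compound 1 by bromo in place of chloro on an aromatic carbon. Among the compounds with values here, no measured step bears on this change, and with compound 1 at a limit, no direction can be read. Compound 3 is therefore expected to stay at or near that limit, with a step that the limit leaves unreadable from compound 1 to compound 3 expected to lie within the scatter. The estimate for compound 3 is 15000 nM, ranging from 5000 nM to 50000 nM.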

Compound 3, half-maximal inhibitory concentration: > 10000 nM
Compound 3 was reported as a limit; the forecaster's own chance of this, stated with the estimate: 85%; the middle value lies beyond the limit too.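

Going by these compounds alone, compound 1 and compound 3 both stand at a limit of the assay, so bromo in place of chloro gives no step that can be read. Still open, going by these compounds, is whether any compound sharing this core gives a measurable value in this assay.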